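Swapping Chloro for Fluoro in a Weakly Cytotoxic Series

A few compounds are considered here, and "the series" means these few. Any claim that something is new, unique, unknown or untested is made for them only; others in the source may bear on it.

Compound 1 `Cc1cccc(Cn2cc(COc3ccc4c(=O)ccoc4c3)nn2)c1` and compound 2 `O=c1ccoc2cc(OCc3cn(Cc4ccccc4Cl)nn3)ccc12` share the same core and differ only in the substituted phenyl on a saturated chain carbon bound to an aromatic nitrogen. In a functional assay on A549 cells (Homo sapiens) for cytotoxicity, read by MTT assay, with a stated time of 48 h (on this read-out higher numbers stand for weaker inhibition and lower numbers for stronger inhibition), compound 1 gives 20300 nM. In this assay compound 2 gives only a limit, > 100000 nM. The step of an at least 4.9-fold higher number from compound 1 to compound 2 (0.69 log units; beyond the scatter) therefore cannot be sized precisely, since it rests on (the limit of > 100000 nM in this assay, at which 1 of the 2 values shown sits). On the numbers shown, compound 2 stands at the weak end. Compound 3 `O=c1ccoc2cc(OCc3cn(Cc4ccccc4F)nn3)ccc12` differs from compound 2 by fluoro in place of chloro on an aromatic carbon. Going by the values given here, no measured step covers this exchange; the single measured step, an at least 4.9-fold higher number from compound 1 to compound 2 (0.69 log units; beyond the scatter), concerns a different change and only shows that compound 2 is weak. For the step that the limit leaves unreadable from compound 2 to compound 3 no change beyond the scatter is expected, so compound 3 will probably also sit near the limit. Compound 3 is expected to give 120000 nM, in the range 30000 nM to 400000 nM.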

Compound 3, half-maximal inhibitory concentration: 10800 nM
For compound 3 the middle estimate is 11-fold (1.05 log units) above the measured one; the whole stated range lies above it.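

In this assay, exchanging chloro for fluoro on this aromatic carbon, ortho to a large group, is far from a silent swap: the data show an at least 9.2-fold lower number from compound 2 to compound 3 (0.96 log units; beyond the scatter). Only a lower bound on the size of this step is known, because compound 2 stands at a limit of the assay: the limit of > 100000 nM in this assay, at which 1 of the 3 values shown sits.

Set against the 3-methylphenyl group, the 2-fluorophenyl group gives a 1.9-fold lower number from compound 1 to compound 3 (0.27 log units; within the scatter), so compound 2 alone stands apart among the three. The compounds shown leave open how other groups at this same place would behave, such as a bromo atom, a methoxy group or an amine. They also leave open whether chloro and fluoro would differ as sharply elsewhere on the phenyl ring, and whether the same gap would appear in other cell lines.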